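From carboxymethyl to oxolan-2-yl on the shared core

The compounds below may be only part of what the source reports. "The series", "measured", "known", "first", "only" and "open" are said of these compounds alone.

In a physicochemical assay for solubility, in phosphate buffer, at pH 7.4 (on this read-out higher numbers stand for higher solubility and lower numbers for lower solubility), compound 1 `CCn1cc(C(=O)C(=O)Nc2ccc(OC)nc2)c2ccccc21` gives 10000 nM as its reading.

In this assay, compound 2 `COc1ccc(NC(=O)C(=O)c2cn(CCC(=O)O)c3ccccc23)cn1` is reported as <= 200000 nM, which is a limit and not a number. Its standing among the measurements amounts to the limit of <= 200000 nM in this assay, at which 1 of the 2 values shown sits, so it has no exact place on the scale.

Compound 3 `COc1ccc(NC(=O)C(=O)c2cn(CC3CCCO3)c3ccccc23)cn1` has oxolan-2-yl in place of carboxymethyl on a saturated chain carbon bound to an aromatic nitrogen, and the full difference reads oxolan-2-yl in place of carboxymethyl on a saturated chain carbon bound to an aromatic nitrogen in the counted terms.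

Within the data shown here, the one measured step bearing on this change is a step that the limit leaves unreadable from compound 1 to compound 2, which introduces the carboxy group that compound 3 does not carry. Its size cannot be read, so it offers no measured size to carry over. Among the measured compounds shown here, with no carboxy group in either structure, compound 3 is expected to read close to compound 1 at 10000 nM in this assay, the only true number available.

That expectation implies an estimated step that the limit leaves unreadable from compound 2 to compound 3, measured against a limit and so only loosely sized, with a lower reading as the likely direction.

The estimate for compound 3 is 15000 nM, with an expected range from 4000 nM to 60000 nM.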

Compound 3, solubility: 10000 nM
Estimate against measurement, compound 3: 1.5-fold (0.18 log units) above, and the stated range covers the measured number.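

Set on a saturated chain carbon bound to an aromatic nitrogen, oxolan-2-yl in place of methyl gives no change at the digits printed from compound 1 to compound 3 (within the scatter) in this assay. Among these compounds, this is the first pair at this position with a true number on both sides, and it shows that the reading stays within the scatter when a simple chain end gives way to a five-membered non-aromatic ring with one hetero atom. The steps involving compound 2 cannot be read, because that compound has only a limit and not a number: the limit of <= 200000 nM in this assay, at which 1 of the 3 values shown sits.

As far as these compounds go, the size of any difference between the carboxymethyl group of compound 2 and the groups on compound 1 and compound 3 therefore stays open, as does whether the carboxylic acid changes the reading in this assay at all. Also open, from the compounds shown here alone, is how an amine, a longer chain or an open-chain ether at this same place would read, so two true numbers at this position support no wider pattern.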